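Replacing a difluorophenyl with a pyrrolidinylpyridine on the thiazole core

A few compounds are considered here, and "the series" means these few. Any claim that something is new, unique, unknown or untested is made for them only; others in the source may bear on it.

Measured so far:
compound 1, `O=C(O)Cc1sc(COc2ccc(Cl)cc2)nc1-c1ccc(Cl)cc1`, gives 32 nM
compound 2, `O=C(O)Cc1sc(C(c2ccc(F)cc2)c2ccc(F)cc2)nc1-c1cc(F)cc(F)c1`, gives 35 nM

Of the compounds shown here, two have been measured in an in vitro assay on HEK385-7 cells for displacement of a labelled ligand from prostaglandin D2 receptor 2 (Homo sapiens); on this read-out lower numbers stand for stronger inhibition and higher numbers for weaker inhibition. Compound 1 gives 32 nM, and compound 2 gives 35 nM. Compound 2 holds the higher of the two numbers, but the two values lie within the usual scatter of each other, so the data show no difference between them.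

Compound 3, `O=C(O)Cc1sc(C(c2ccc(F)cc2)c2ccc(F)cc2)nc1-c1ccnc(N2CCCC2)c1`, has not yet been measured. It differs from compound 2 in one place: 2-(pyrrolidin-1-yl)pyridin-4-yl in place of 3,5-difluorophenyl on an aromatic carbon. Among the compounds with values here, no step between measured compounds speaks to a change of this kind, so nothing here says how the two aromatic rings compare.

In this assay the step of a 1.4-fold higher number from compound 2 to compound 3 (0.15 log units; within the scatter) is expected to stay within the usual scatter, in either direction. Compound 3 is therefore estimated at 50 nM, with a range from 12 nM to 200 nM.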

Compound 3, half-maximal inhibitory concentration: 230 nM
Compound 3: the middle estimate sits 4.6-fold (0.66 log units) below what was measured; measured number above the stated range.
By their numbers in this assay, from the lowest: compounds 1 and 2 (each within the scatter of the next); then compound 3.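

Within the data shown here, at this aromatic carbon of the shared core, the earlier compounds gave no sign of how much the ring matters, but in this assay the change from 3,5-difluorophenyl to 2-(pyrrolidin-1-yl)pyridin-4-yl gives a 6.6-fold higher number from compound 2 to compound 3 (0.82 log units; beyond the scatter). The position therefore does respond to the identity of its aromatic substituent, and this larger group, with its ring nitrogen and attached pyrrolidine, is the less favourable of the two on this read-out. Nothing measured here accounts for the loss.

The pyridine ring and the pyrrolidine enter together, so the compounds shown leave open which of the two carries the step. A plain pyridin-4-yl would separate them, and a 2-(morpholin-4-yl)pyridin-4-yl or a 2-(dimethylamino)pyridin-4-yl would test whether the size or nature of the amine matters at this position.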